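Chloro to Nitro on Compound 3

The compounds below may be only part of what the source reports. "The series", "measured", "known", "first", "only" and "open" are said of these compounds alone.

In an ADME assay on Vero cells (Chlorocebus sabaeus) for cytotoxicity, read by resazurin assay, with a stated time of 72 h (on this read-out higher numbers stand for weaker inhibition and lower numbers for stronger inhibition), compound 3 `O=C(CCN1CCN(c2ccc(Cl)cc2)CC1)c1ccc(F)c(Cl)c1` gives 114000 nM. Compound 2 `O=C(CCN1CCN(c2ccc([N+](=O)[O-])cc2)CC1)c1ccc(Br)cc1` gives 79800 nM, within the scatter of compound 3. Compound 1 `Cc1ccc(C(=O)CCN2CCN(c3ccc([N+](=O)[O-])cc3)CC2)cc1` gives 235000 nM, the highest of the three numbers and beyond the scatter from both others.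

Compound 4 `O=C(CCN1CCN(c2ccc([N+](=O)[O-])cc2)CC1)c1ccc(F)c(Cl)c1` follows from compound 3 through one change: nitro in place of chloro on an aromatic carbon. This places nitro in place of chloro on an aromatic carbon, turning 4-chlorophenyl into 4-nitrophenyl. Among the measured compounds shown here, no measured pair makes this exchange directly. For the measured compounds named here, the only measured step, a 2.9-fold lower number from compound 1 to compound 2 (0.47 log units; beyond the scatter), is modest and puts bromo in place of methyl, so it bears on the change only indirectly. It does show that, with the same 4-nitrophenyl as compound 4 along with a halogen on its other aromatic ring, compound 2 reads 79800 nM. A shift beyond the scatter is therefore not expected, and the estimated step is a 1.2-fold lower number from compound 3 to compound 4 (0.08 log units; within the scatter). Compound 4 is estimated at 95000 nM, with an expected range of 45000 nM to 200000 nM.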

Compound 4, half-maximal inhibitory concentration: 116000 nM
Beside the measured number, compound 4's estimate is 1.2-fold (0.09 log units) below it; low and high end bracket the measured number.
By their numbers in this assay, from the lowest: compounds 2, 3 and 4 (each within the scatter of the next); then compound 1.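

In this assay, the exchange of chloro for nitro now has a direct reading (a 1.0-fold higher number from compound 3 to compound 4 (0.01 log units; within the scatter)): with 3-chloro-4-fluorophenyl held on the carbonyl carbon, 4-chlorophenyl and 4-nitrophenyl read alike. With 4-nitrophenyl held, the group on the carbonyl carbon can also be compared: 3-chloro-4-fluorophenyl in place of 4-bromophenyl stays within the scatter (a 1.5-fold higher number from compound 2 to compound 4 (0.16 log units; within the scatter)), while in place of 4-methylphenyl it gives a modest step beyond the scatter (a 2.0-fold lower number from compound 1 to compound 4 (0.31 log units; beyond the scatter)). No measurement shown accounts for these readings.

On these data alone, the exchange of chloro for nitro is seen in this one pair only, so whether it reads the same with another group on the carbonyl carbon stays open. The compounds shown also leave open how an amine or a carboxylic acid would read on this aromatic carbon.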